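A few compounds are considered here, and "the series" means these few. Any claim that something is new, unique, unknown or untested is made for them only; others in the source may bear on it.

Within the data shown here, compound 3 `CCCCCCC#Cc1c(CCCCCC)oc2nc(=O)n(Cc3cn(Cc4ccccc4)nn3)cc12` is the one member of this small set that returns a number in a functional assay on HeLa cells (Homo sapiens) for antiproliferative activity, read by MTT assay, with a stated time of 72 h; on this read-out lower numbers stand for stronger inhibition and higher numbers for weaker inhibition: compound 3 gives 23400 nM. Compound 2 `CCCCCCC#Cc1c(CCCCCC)oc2nc(=O)n(Cc3cn(-c4ccc(F)cc4)nn3)cc12` returns only a limit, which for compound 2 in this assay stands at > 100000 nM. Compound 1 `CCCCCCc1cc2cn(Cc3cn(-c4ccccc4F)nn3)c(=O)nc2o1` likewise returns only a limit, in this assay at > 100000 nM. Among the measured compounds shown here, the single measured step is an at least 4.2-fold lower number from compound 2 to compound 3 (0.63 log units; beyond the scatter). Compound 4 `CCCCCCc1cc2cn(Cc3cn(Cc4ccccc4)nn3)c(=O)nc2o1` is derived from compound 3 by hydrogen in place of oct-1-yn-1-yl on an aromatic carbon. For the measured compounds named here, no measured step touches this change: compound 1, which also lacks the oct-1-yn-1-yl group, and compound 2, which carries it, both sit at the limit of > 100000 nM in this assay, at which 2 of the 3 values shown sit, and the two also differ in a second place, so neither reveals what removal of that group does on its own. Given that compound 3 sits at 23400 nM, the step in this assay is expected to be a 2.1-fold higher number from compound 3 to compound 4 (0.33 log units; beyond the scatter), toward weaker inhibition. Compound 4 is therefore estimated at 50000 nM, within a range from 15000 nM to 200000 nM.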

Compound 4, half-maximal inhibitory concentration: 59400 nM
Estimate against measurement, compound 4: 1.2-fold (0.07 log units) below, and the stated range covers the measured number.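

In this assay, the loss of the oct-1-yn-1-yl group now has a size of its own, with the benzyl group held constant: a 2.5-fold higher number from compound 3 to compound 4 (0.40 log units; beyond the scatter). Compound 4 still returns a number, so inhibition in this assay does not disappear when that group gives way to hydrogen. Without the oct-1-yn-1-yl group, the change to benzyl from 2-fluorophenyl gives an at least 1.6-fold lower number from compound 1 to compound 4 (0.22 log units; that floor lies within the scatter), and since this step rests on a limit for compound 1, it does not show whether benzyl improves on that aryl group here.

The compounds shown leave open whether the triple bond or the chain itself carries the step, which a saturated octyl chain or a shorter alkynyl chain at this carbon would help separate. How far the compounds reported only as limits lie from the others cannot be read: the limit of > 100000 nM in this assay, at which 2 of the 4 values shown sit.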